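This account rests on a few compounds, and the source may have more. Where it says the series, first, only, none or still open, it means among the compounds named here.

Working notes on the series.

The series is built on one core: compound 1 `CCOC(=O)CCO/N=C(/c1ccc(OC)c(OC)c1OC)c1cccc2ccccc12`, compound 2 `COc1ccc(C(c2ccccc2O)c2cccc3ccccc23)c(OC)c1OC` and the unmeasured compound 3 `C=CCOC(c1ccc(OC)c(OC)c1OC)c1cccc2ccccc12`. Inhibition is read in a functional assay on THP-1 cells (Homo sapiens) for inhibition, read by sulforhodamine B assay, with a stated time of 48 h; on this read-out higher numbers stand for weaker inhibition and lower numbers for stronger inhibition. In this assay compound 1 gives only a limit, > 20000 nM, and no number. In this assay compound 2 likewise gives only a limit, > 20000 nM. For the measured compounds named here, compound 2 therefore stands at the limit of > 20000 nM in this assay, at which 2 of the 2 values shown sit; both values shown are limits, so no ordering of compound 1 against compound 2 can be made, and no step between measured compounds is available.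

Compound 3 differs from compound 2 in one place: allyloxy in place of 2-hydroxyphenyl on a saturated chain carbon bound to two aromatic carbons. With nothing but limits as reference, the size of the change expected from compound 2 to compound 3 in this assay cannot be read from measured steps; the expectation is that compound 3 stays near the limit, with no move beyond the scatter, and the step that the limit leaves unreadable from compound 2 to compound 3 is an estimate only.

Compound 3 is expected to give about 25000 nM in this assay, within a range from 8000 nM to 80000 nM, most likely reported again as a limit.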

Compound 3, half-maximal inhibitory concentration: > 20000 nM
Compound 3 ended at the assay's limit (the forecaster's own chance of this, stated with the estimate: 75%); the middle value is on the limit's open side.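

In this assay compound 3 gives > 20000 nM as a limit and not a number. No step can be read from compound 2 to compound 3, and the compounds cannot be ordered: the limit of > 20000 nM in this assay, at which 3 of the 3 values shown sit. The compounds shown leave open whether any change on the shared core gives a value in this assay that is a number rather than a limit.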